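Aryl Variation on the Ring Nitrogen of the Shared Core

The compounds below may be only part of what the source reports. "The series", "measured", "known", "first", "only" and "open" are said of these compounds alone.

Compound 1 `O=C(NCCCCc1ccccc1)c1cccc(C2SCC(=O)N2c2ccc(-c3ccccc3)cc2)c1` is reported in a functional assay on HOS-TE85 cells (Homo sapiens) for inhibition, read by CCK-8 assay, with a stated time of 72 h (a higher number here means a weaker inhibitor, a lower number a stronger inhibitor), only as a limit, > 1000 nM. Compound 2 `COc1ccc(OC)c(N2C(=O)CSC2c2cccc(C(=O)NCCCCc3ccccc3)c2)c1` likewise gives only a limit, > 1000 nM. Going by the values given here, compound 3 `COc1c(F)cccc1N1C(=O)CSC1c1cccc(C(=O)NCCCCc2ccccc2)c1` gives 26.2 nM, the only number among the three values shown. The remaining two values are covered by the limit of > 1000 nM in this assay, at which 2 of the 3 values shown sit. Both measured steps onto compound 3 were large: an at least 38-fold lower number from compound 1 to compound 3 (1.58 log units; beyond the scatter) and an at least 38-fold lower number from compound 2 to compound 3 (1.58 log units; beyond the scatter). Compound 4 `CC(F)(F)c1cccc(N2C(=O)CSC2c2cccc(C(=O)NCCCCc3ccccc3)c2)c1` is not yet measured; it differs from compound 3 thus: a group of 10 heavy atoms (8 carbon, 2 fluorine; one six-membered aromatic ring of carbon only) in place of a group of 9 heavy atoms (7 carbon, 1 oxygen, 1 fluorine; one six-membered aromatic ring of carbon only), on an amide-type nitrogen in a ring. The measured steps show that the group on the amide-type nitrogen in the ring decides whether a number appears at all, yet none of them tests this particular group. A weaker result than compound 3 is expected, a 5.7-fold higher number from compound 3 to compound 4 (0.76 log units; beyond the scatter), with wide uncertainty. Compound 4 is estimated at 150 nM, between 25 nM and 1000 nM.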

Compound 4, half-maximal inhibitory concentration: 29.1 nM
Compound 4: the middle estimate sits 5.2-fold (0.71 log units) above what was measured; measured number inside the range.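

In this assay, the exchange gives a 1.1-fold higher number from compound 3 to compound 4 (0.05 log units; within the scatter), so a number in this range does not depend on the oxygen of 3-fluoro-2-methoxyphenyl or on a hydrogen-bond acceptor in the group on this nitrogen. The group of compound 4 also separates from the other two aryl groups, with an at least 34-fold lower number from compound 2 to compound 4 (1.53 log units; beyond the scatter) and an at least 34-fold lower number from compound 1 to compound 4 (1.53 log units; beyond the scatter). Both steps rest on a limit rather than a number: the limit of > 1000 nM in this assay, at which 2 of the 4 values shown sit.

From the compounds shown here alone, what an amine or a carboxylic acid on the aryl group at this nitrogen would give remains open.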